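Shortening the Alkyl Chain from Dodecyl to Decyl

The compounds below may be only part of what the source reports. "The series", "measured", "known", "first", "only" and "open" are said of these compounds alone.

Compound 1 `CCCCCCCCCC/N=C1/SC[C@@H]2[C@@H](O)[C@H](O)[C@@H](CO)N12` gives 93000 nM in an assay for inhibition of beta-galactosidase (Bos taurus), read by spectrophotometry; a lower number here means a stronger inhibitor, a higher number a weaker inhibitor.
Compound 2 `CCCC/N=C1/SC[C@H]2[C@H](O)[C@@H](O)[C@H](CO)N12` gives 719000 nM in this assay.
Compound 3 `CCCCCCCCCCCC/N=C1/SC[C@H]2[C@H](O)[C@@H](O)[C@H](CO)N12` gives 11000 nM in this assay.

Compound 3 has the lowest number of the three in this assay; compound 1 stands nearest to it and compound 2 furthest, both gaps beyond the scatter. Compound 4 `CCCCCCCCCC/N=C1/SC[C@H]2[C@H](O)[C@@H](O)[C@H](CO)N12` differs from compound 3 by hydrogen in place of ethyl on a saturated chain carbon, ten or more bonds along the chain from a double-bonded nitrogen. Going by the values given here, the only measured step that bears on chain length is a 65-fold lower number from compound 2 to compound 3 (1.82 log units; beyond the scatter), where a longer chain went with a much lower number. Cutting the chain back by an ethyl is therefore expected to move the number in this assay upward by a moderate step, a 3.2-fold higher number from compound 3 to compound 4 (0.50 log units; beyond the scatter). Compound 4 is expected to give 35000 nM, with a range from 12000 nM to 110000 nM.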

Compound 4, half-maximal inhibitory concentration: 36000 nM
Compound 4: the middle estimate sits 1.0-fold (0.01 log units) below what was measured; the measured number falls inside the stated range.
By their numbers in this assay, from the lowest: compound 3; then compound 4; then compound 1; then compound 2.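

In this assay, removing the ethyl gave a 3.3-fold higher number from compound 3 to compound 4 (0.51 log units; beyond the scatter) and so the number still responds to the loss of an ethyl from the chain. Against the butyl chain, the decyl chain gave a 20-fold lower number from compound 2 to compound 4 (1.30 log units; beyond the scatter) and so the number falls in order through butyl, decyl and dodecyl in this configuration. With the decyl chain unchanged, configuration alone accounts for a 2.6-fold lower number from compound 1 to compound 4 (0.41 log units; beyond the scatter) and the reason this gap can be assigned to it is: the fact that compounds 1 and 4 differ only in the configuration as drawn

Going by these compounds, whether the number keeps falling with a chain longer than dodecyl, or how a chain ending in an amine would read, remains open. Which of the differing stereocentres matters also remains open.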